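Chloro for sulfamoyl on the aryl amine of compound 3

A few compounds are considered here, and "the series" means these few. Any claim that something is new, unique, unknown or untested is made for them only; others in the source may bear on it.

Measured in a functional assay on the whole organism (strain Albino) for inhibition, with Mus musculus as the target, in the writhing test, at a dose of 50 mg/kg by the oral route (a lower number here means less inhibition, a higher number more inhibition at the dose given (going by the name of the read-out)), so far:
compound 1, `CCOC(=O)c1c(NC(C)C)ncnc1Oc1ccccc1`: 70.2%
compound 2, `CCOC(=O)c1c(Nc2ccc([N+](=O)[O-])cc2)ncnc1NC(C)C`: 77.4%
compound 3, `CCOC(=O)c1c(Nc2ccc(S(N)(=O)=O)cc2)ncnc1NC(C)C`: 72.6%

Compound 3 stands with the second highest of the three numbers, but its gaps to compound 1 and to compound 2 both lie within the scatter, so the three measured compounds cannot be told apart on these data.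

Compound 4, `CCOC(=O)c1c(Nc2ccc(Cl)cc2)ncnc1NC(C)C`, is not yet measured. It differs from compound 3 by chloro in place of sulfamoyl on an aromatic carbon.

Going by the values given here, the one measured step that bears on this change is a number 4.8 percentage points lower from compound 2 to compound 3 (within the scatter), an exchange of one group for another on the same aromatic carbon, and it stayed within the scatter. Among the compounds with values here, only one such step exists, so the expectation rests on a single comparison. The exchange of sulfamoyl for chloro is therefore expected to move this assay by no more than the scatter, in no particular direction.

Compound 4 is expected to give about 73%, with a range from 60% to 85%. The expected step is a number 0.4 percentage points higher from compound 3 to compound 4 (within the scatter), within the scatter.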

Compound 4, a percentage reported as inhibition, in the whole organism at one dose (the size of the read-out at that dose, not a potency): 70.2%
Compound 4: middle estimate off by 2.8 percentage points, on the high side, within the range that was stated.
By their numbers in this assay, from the lowest: compounds 1, 4, 3 and 2 (each within the scatter of the next).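

In this assay, chloro in place of sulfamoyl on this aromatic carbon gives a number 2.4 percentage points lower from compound 3 to compound 4 (within the scatter), and chloro in place of nitro gives a number 7.2 percentage points lower from compound 2 to compound 4 (within the scatter). The position, para to a large group, now holds three different groups with no step beyond the scatter, and this includes the exchange of sulfamoyl, with 4 heavy atoms and a hydrogen-bond donor, for chloro, with 1 heavy atom and no donor. No measurement offers an explanation for these steps.

From the compounds shown here alone, whether an amine, a carboxylic acid or a longer chain such as butyl on this carbon would give a step beyond the scatter stays open. Going by these compounds, since this assay reports a single dose, it also remains open whether these compounds separate at other doses.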